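Adding a Chlorine Atom to Compound 3

The compounds below may be only part of what the source reports. "The series", "measured", "known", "first", "only" and "open" are said of these compounds alone.

Of the compounds shown here, three sharing one core have been tested in a functional assay on the whole organism (strain CD-1 Charles River) for inhibition, with Mus musculus as the target, in the writhing test, with stated times of 90 min and 5 min, at a dose of 25 mg/kg by the subcutaneous route; on this read-out higher numbers stand for more inhibition at the one dose given (going by the name of the read-out) and lower numbers for less inhibition. Compound 1 `O=C1c2cc(Cl)ccc2Oc2ccccc2C12CCN(CC1CC1)CC2` gives 31%, compound 2 `O=C(CCCN1CCC2(CC1)C(=O)c1cc(Cl)ccc1Oc1ccccc12)c1ccc(F)cc1` gives 49%, and compound 3 `O=C1c2ccccc2Oc2ccccc2C12CCN(CCCOc1ccccc1)CC2` gives 55%, the highest of the three numbers, although compound 2 lies within the scatter of it. Compound 4 `O=C1c2cc(Cl)ccc2Oc2ccccc2C12CCN(CCCOc1ccccc1)CC2` differs from compound 3 by chloro in place of hydrogen on an aromatic carbon. For the measured compounds named here, the only measured step, a number 18 percentage points higher from compound 1 to compound 2 (beyond the scatter), alters the group on the amine nitrogen rather than the aromatic ring, so no measured step bears on adding chloro; compound 2, which carries chloro, shows a number within the scatter of compound 3. Little change is therefore expected. Compound 4 is estimated at 55%, between 40% and 70%. The expected step of no change at the digits printed from compound 3 to compound 4 (within the scatter) lies within the scatter.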

Compound 4, a percentage reported as inhibition, in the whole organism at one dose (the size of the read-out at that dose, not a potency): 54%
Estimate against measurement, compound 4: 1 percentage points above, and the stated range covers the measured number.
By their numbers in this assay, from the lowest: compound 1; then compounds 2, 4 and 3 (each within the scatter of the next).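

In this assay, for the compounds shown here, the step of a number 1 percentage points lower from compound 3 to compound 4 (within the scatter) for chloro in place of hydrogen on this aromatic carbon gives the first direct reading of this change, and the number does not move beyond the scatter. With chloro on the shared core, the step of a number 5 percentage points higher from compound 2 to compound 4 (within the scatter) for phenoxy in place of (4-fluorophenyl)carbonyl stays small, while the step of a number 23 percentage points higher from compound 1 to compound 4 (beyond the scatter) for 2-phenoxyethyl in place of cyclopropyl is clearly larger. Nothing measured here offers an explanation for these results. Going by these compounds, whether an amine or a carboxylic acid on this aromatic carbon would shift the number remains open.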